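Urea-to-acylsemicarbazide exchange on a hydroxamic acid hybrid

A few compounds are considered here, and "the series" means these few. Any claim that something is new, unique, unknown or untested is made for them only; others in the source may bear on it.

Measured so far:
- Compound 1, `COc1cc2c(Oc3ccc(NC(=O)Nc4ccccc4)cc3)ccnc2cc1OCCCCCCC(=O)NO`: 1650 nM
- Compound 2, `COc1cc2c(Oc3ccc(NC(=O)Nc4ccc(C)cc4C)cc3)ccnc2cc1OCCCCCCC(=O)NO`: 5490 nM

Among the measured compounds shown here, in a functional assay on A549 cells (Homo sapiens) for antiproliferative activity, read by MTT assay (on this read-out lower numbers stand for stronger inhibition and higher numbers for weaker inhibition), compound 2 gives the highest of the two numbers; its only neighbour is compound 1, and the step of a 3.3-fold higher number from compound 1 to compound 2 (0.52 log units; beyond the scatter) came with 2,4-dimethylphenyl in place of phenyl on an amide-type nitrogen. The unmeasured compound 3, `COc1cc2c(Oc3ccc(NC(=O)NNC(=O)c4ccccc4F)cc3)ccnc2cc1OCCCCCCC(=O)NO`, differs from compound 2 by ((2-fluorophenyl)carbonyl)amino in place of 2,4-dimethylphenyl on an amide-type nitrogen. For the measured compounds named here, no measured step covers a change of this kind: the single known step swaps one carbon-only aromatic ring for another, whereas here a ring with a donor and acceptor enters. The direction is therefore open; a modest step in either direction, or none beyond the scatter, is plausible. The number for compound 3 is estimated near 3500 nM, with a range of 900 nM to 14000 nM. This estimate corresponds to an expected step of a 1.6-fold lower number from compound 2 to compound 3 (0.20 log units; within the scatter).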

Compound 3, half-maximal inhibitory concentration: 2420 nM
Estimate against measurement, compound 3: 1.4-fold (0.16 log units) above, within the range that was stated.
By their numbers in this assay, from the lowest: compounds 1 and 3 (each within the scatter of the next); then compound 2.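

In this assay, placing ((2-fluorophenyl)carbonyl)amino on the amide-type nitrogen instead of 2,4-dimethylphenyl gives a 2.3-fold lower number from compound 2 to compound 3 (0.36 log units; beyond the scatter), so this position responds to more than a swap of one carbon-only ring for another. Placing the same group there instead of plain phenyl gives a 1.5-fold higher number from compound 1 to compound 3 (0.17 log units; within the scatter), which means that compound 1 and compound 3 cannot be told apart on this read-out, even though the group in compound 3 adds a carbonyl, a nitrogen, a hydrogen-bond donor and a hydrogen-bond acceptor. No available evidence accounts for these numbers.

Compound 3 brings in the fluorine together with the carbonyl and the extra nitrogen, so the share of each in the step cannot be separated. Going by these compounds, how a plain benzoyl group, or a ring carrying a methoxy group or an amine, would read at this position remains open.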